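Methylsulfanyl for Iodo on a Boron-Containing Chalcone

This account rests on a few compounds, and the source may have more. Where it says the series, first, only, none or still open, it means among the compounds named here.

Of the compounds shown here, two have been measured in a functional assay on SK-OV-3 cells (Homo sapiens) for cytotoxicity, read by MTT assay, with a stated time of 48 h; a higher number here means a weaker inhibitor, a lower number a stronger inhibitor. Compound 1 `O=C(/C=C/c1ccc2c(c1)B(O)OC2)c1ccc(-c2ccccc2)cc1` gives 4900 nM. Compound 2 `O=C(/C=C/c1ccc2c(c1)B(O)OC2)c1ccc(I)cc1` gives 4200 nM, the lowest of the two numbers, and the step of a 1.2-fold lower number from compound 1 to compound 2 (0.07 log units; within the scatter) is the only one measured so far. Compound 3 `CSc1ccc(C(=O)/C=C/c2ccc3c(c2)B(O)OC3)cc1` has not been measured. It differs from compound 2 in one place: methylsulfanyl in place of iodo on an aromatic carbon.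

Going by the values given here, the one measured step that bears on this change, a 1.2-fold lower number from compound 1 to compound 2 (0.07 log units; within the scatter), varies the same aromatic carbon of compound 2 and stays within the scatter. Nothing in the two numbers points to a large effect of exchanging a group at this position. Compound 3 is therefore expected to show a step of a 1.1-fold higher number from compound 2 to compound 3 (0.03 log units; within the scatter), meaning no change beyond the scatter. The estimate for compound 3 in this assay is 4500 nM, with a range from 2000 nM to 10000 nM.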

Compound 3, half-maximal inhibitory concentration: 4100 nM
Estimate against measurement, compound 3: 1.1-fold (0.04 log units) above; the measured number falls inside the stated range.
By their numbers in this assay, from the lowest: compounds 3, 2 and 1 (each within the scatter of the next).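

The change from iodo to methylsulfanyl, on an aromatic carbon para to a large group, gives in this assay a 1.0-fold lower number from compound 2 to compound 3 (0.01 log units; within the scatter) and the change from phenyl to methylsulfanyl gives a 1.2-fold lower number from compound 1 to compound 3 (0.08 log units; within the scatter) so all three compounds now lie within the scatter of one another. The entering methylsulfanyl brings one hydrogen-bond acceptor where iodo has none, and this adds no step beyond the scatter, which extends the earlier comparison of phenyl and iodo to a third group at the same carbon. Nothing available explains why these three groups give such close numbers.

On these data alone, whether an amine or a carboxylic acid on this carbon would also stay within the scatter remains open. So does whether a change elsewhere on the shared core would move the number in this assay.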